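A few compounds are considered here, and "the series" means these few. Any claim that something is new, unique, unknown or untested is made for them only; others in the source may bear on it.

Measured so far:
compound 1 `Cc1c(C(C)OC(=O)Nc2ccccc2)oc2nc(C3CC3)nn12`, 12.6 nM
compound 2 `Cc1c(COC(=O)Nc2ccccc2)sc2ncnn12`, > 31600 nM
compound 3 `O=C(Nc1ccccc1)OCc1cn2ncnc2s1`, > 31600 nM

In a functional assay on CHO cells for antagonist activity at metabotropic glutamate receptor 5 (Homo sapiens), read by calcium flux (on this read-out higher numbers stand for weaker inhibition and lower numbers for stronger inhibition), compound 2 gives only a limit, > 31600 nM. Compound 3 likewise gives only a limit, > 31600 nM. Within the data shown here, the one single-point step measured, a step that the two limits leave unreadable from compound 2 to compound 3, stays unreadable because both ends sit at the limit of > 31600 nM in this assay, at which 2 of the 3 values shown sit. Compound 1 gives a number, 12.6 nM, but it differs from compound 2 in more than one place, so only its value is noted.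

Compound 4 `Cc1c([C@H](C)OC(=O)Nc2ccccc2)sc2ncnn12` differs from compound 2 by methyl in place of hydrogen on a saturated chain carbon bound to an aromatic carbon and an oxygen next to a carbonyl group. Among the measured compounds shown here, no readable measured step bears on this change; the only step on record is unreadable in size. Compound 4 is therefore expected near 20000 nM, in the range 1000 nM to 31600 nM. The expected step is an at least 1.5-fold lower number from compound 2 to compound 4 (0.19 log units; that floor lies within the scatter).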

Compound 4, half-maximal inhibitory concentration: > 10000 nM
Compound 4: no number, only a limit (the forecaster's own chance of this, stated with the estimate: 55%); the middle value does not contradict the limit.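

Compound 4 gives only a limit, > 10000 nM, and compound 2 also stands at a limit, so the step between them cannot be read. The compounds shown leave open whether this methyl changes inhibition at all.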